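The source may hold more compounds than are shown below. What is called first, only, known or untested is meant among the compounds shown, and "the series" means these compounds.

Within the data shown here, compound 1, with the structure `Nc1nc(SCc2ccccc2)nc2c1nc(O)n2Cc1ccccc1`, is the only member of this small set for which a number is known: in a functional assay (spleen, spleen) for activation, with Mus musculus as the target (on this read-out lower numbers stand for an effect already at smaller amounts and higher numbers for an effect only at larger amounts of compound), compound 1 gives 0.1 uM. Compound 2, with the structure `Nc1ncnc2c1nc(Cl)n2Cc1ccccc1`, reaches only a limit of this assay, > 10 uM. Compound 3, with the structure `Nc1ncnc2c1nc(O)n2C1CCCC1`, likewise reaches only a limit of this assay, > 10 uM. Among the measured compounds shown here, two of the three values therefore stop at the same point, (the limit of > 10 uM in this assay, at which 2 of the 3 values shown sit), and there is no pair of measured compounds that differ in one place, so no step between measured compounds can be read.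

Compound 4, with the structure `CCCNc1nc(N)c2nc(O)n(Cc3ccccc3)c2n1`, has not been measured. It differs from compound 1 in one spot: propylamino in place of benzylsulfanyl on an aromatic carbon. The spot is between two ring nitrogen atoms of the shared core. Nothing in the measured set tells how a change at this spot shifts this read-out, since compound 1 stands alone with its number. The expectation for compound 4 is a shift of a 10-fold higher number from compound 1 to compound 4 (1.00 log units; beyond the scatter), which is more than the usual scatter but far short of the limit. The estimate for compound 4 in this assay is 1 uM, with a range from 0.1 uM to 10 uM.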

Compound 4, minimum effective concentration: 0.1 uM
Compound 4: middle estimate off by 10-fold (1.00 log units), on the high side; measured number inside the range.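

In this assay, among these compounds, the swap of benzylsulfanyl for propylamino gives no change at the digits printed from compound 1 to compound 4 (within the scatter), the first reading of any change at this spot between two ring nitrogen atoms. The sulfur and the six-membered aromatic ring of benzylsulfanyl are therefore not needed here to keep this read-out, and a shorter group with no ring and with a hydrogen-bond donor serves equally well in this pair. Why the two groups match cannot be said from these data, and nothing measured here speaks to a cause.

The compounds shown leave open how much room this spot allows: a longer chain such as hexylamino, a plain amino group or a carboxylic acid might keep the read-out or might move it. Among the compounds shown here, whether the spot needs any group at all also stays open, since compound 2 and compound 3 each differ from compound 1 in more than one place, so no step to either of them can be read.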